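The source may report more compounds than this note shows. Statements on the series, on what has been measured and on what is new or still open speak of the compounds shown alone.

Of the compounds shown here, three built on one shared core have been tested in a functional assay on MCF7 cells (Homo sapiens) for antiproliferative activity, read by MTT assay, with a stated time of 72 h; on this read-out lower numbers stand for stronger inhibition and higher numbers for weaker inhibition. Compound 3 `CCCSc1nc(N/N=C(\C)c2ccccc2O)c2nnn(Cc3ccccc3)c2n1`, which carries a benzyl group, gives 11000 nM. Compound 1 `CCCSc1nc(N/N=C(\C)c2ccccc2O)c2nnn(Cc3ccccc3Cl)c2n1`, with a 2-chlorophenyl in place of that phenyl, reaches only the limit of the assay, > 64000 nM. Compound 2 `CCCSc1nc(N/N=C(\C)c2ccccc2O)c2nnn(Cc3ccc(F)cc3)c2n1`, with a 4-fluorophenyl instead, likewise reaches only the limit, > 64000 nM. Among the three values, compound 3 therefore stands as the only real number, the other two being limits. The two steps that can be read both lead to compound 3: an at least 5.8-fold lower number from compound 1 to compound 3 (0.76 log units; beyond the scatter) and an at least 5.8-fold lower number from compound 2 to compound 3 (0.76 log units; beyond the scatter). Their true sizes cannot be fixed because two of the three values sit at the limit of > 64000 nM in this assay, at which 2 of the 3 values shown sit.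

Compound 4 `CCCSc1nc(N/N=C(\C)c2ccccc2O)c2nnn(Cc3ccco3)c2n1` differs from compound 3 by furan-2-yl in place of phenyl on a saturated chain carbon bound to an aromatic nitrogen. Neither measured step is this change: both concern a halogen on the phenyl, while here the whole phenyl is exchanged for a smaller aromatic ring. Going by the values given here, the only guidance is that the unsubstituted benzyl of compound 3 gave the lowest number seen, so a shift of similar size in either direction cannot be ruled out. Compound 4 is expected to give about 15000 nM, within 4000 nM to 60000 nM. The expected step is a 1.4-fold higher number from compound 3 to compound 4 (0.13 log units; within the scatter), which would stay within the scatter.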

Compound 4, half-maximal inhibitory concentration: 29000 nM
Estimate against measurement, compound 4: 1.9-fold (0.29 log units) below; the measured number falls inside the stated range.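

In this assay, going by these compounds alone, this is the first change on the saturated chain carbon bound to an aromatic nitrogen whose size can be read in full, as two real numbers now stand on either side of it (a 2.6-fold higher number from compound 3 to compound 4 (0.42 log units; beyond the scatter)). It also shows that a ring other than phenyl can sit at this place and still give a real number, since the furan-2-yl of compound 4 keeps activity that the halogen-bearing rings of compound 1 and compound 2, both recorded only at a limit of the assay, do not show (an at least 2.2-fold lower number from compound 2 to compound 4 (0.34 log units; beyond the scatter) and an at least 2.2-fold lower number from compound 1 to compound 4 (0.34 log units; beyond the scatter)). Compound 3 keeps the lowest number of the four, though the two steps just given are only minimum sizes and the step between compound 1 and compound 2 cannot be read: the limit of > 64000 nM in this assay, at which 2 of the 4 values shown sit.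

The compounds shown leave open whether the gain or loss follows the ring itself, as a pyridin-2-yl or thiophen-2-yl ring at this place could tell. They also leave open whether any ring is needed at all, which a cyclohexyl group or a plain butyl chain in place of the benzyl would test.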